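Piperazine amide swap: cyclopentyl for 2-fluorophenyl, solubility

A few compounds are considered here, and "the series" means these few. Any claim that something is new, unique, unknown or untested is made for them only; others in the source may bear on it.

For the measured compounds named here, compound 1 `O=C(c1ccccc1F)N1CCN(c2nc(=O)c3cc(C(F)(F)F)cc([N+](=O)[O-])c3s2)CC1` stands lowest of the two numbers so far: in a physicochemical assay for solubility, read by HPLC (a higher number here means a more soluble compound, a lower number a less soluble compound), compound 1 gives 3.1 ug/mL, while compound 2 `O=C(C1CC1)N1CCN(c2nc(=O)c3cc(C(F)(F)F)cc([N+](=O)[O-])c3s2)CC1` gives 52.9 ug/mL. The step to compound 2 was a 17-fold higher number from compound 1 to compound 2 (1.23 log units; beyond the scatter). Compound 3 `O=C(C1CCCC1)N1CCN(c2nc(=O)c3cc(C(F)(F)F)cc([N+](=O)[O-])c3s2)CC1` carries cyclopentyl in place of 2-fluorophenyl on a carbonyl carbon. Going by the values given here, only that one step bears on it, and it too brings in a non-aromatic ring of carbon only in place of the aryl group, so an upward step in this assay beyond the scatter is expected, though cyclopentyl need not match cyclopropyl. The step from compound 1 to compound 3 is estimated at a 6.5-fold higher number from compound 1 to compound 3 (0.81 log units; beyond the scatter). Compound 3 is expected near 20 ug/mL, within 6 ug/mL to 60 ug/mL.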

Compound 3, solubility: 5.34 ug/mL
Compound 3: middle estimate off by 3.7-fold (0.57 log units), on the high side, outside the stated range (below it).
By their numbers in this assay, from the lowest: compounds 1 and 3 (each within the scatter of the next); then compound 2.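

In this assay, a non-aromatic ring of carbon only in place of 2-fluorophenyl does not by itself set the reading at this carbonyl position: the cyclopentyl change gives (a 1.7-fold higher number from compound 1 to compound 3 (0.24 log units; within the scatter)). Ring identity at this place counts, since cyclopentyl in place of cyclopropyl gives (a 9.9-fold lower number from compound 2 to compound 3 (1.00 log units; beyond the scatter)). Nothing available accounts for this difference between the two rings.

As far as these compounds go, whether cyclobutyl or cyclohexyl would read with compound 2 or with compound 3 remains open. So does the outcome for an open chain such as isopropyl, or for a cyclopentyl ring carrying an amine.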